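Pyrazole swap on the acetamide arm of the series

A few compounds are considered here, and "the series" means these few. Any claim that something is new, unique, unknown or untested is made for them only; others in the source may bear on it.

The series shares the core seen in compound 2 `CCOc1ncc(-c2nc(C(F)(F)F)sc2N2CCN(C(=O)Cn3ccc(C(F)(F)F)n3)[C@H](C)C2)cn1`; compound 1 `CCOc1ncc(-c2nc(C(F)(F)F)sc2N2CCN(C(=O)Cn3nccc3C)[C@H](C)C2)cn1` carries a 5-methyl-1H-pyrazol-1-yl on the same saturated chain carbon bound to a carbonyl carbon. In an assay on blood for inhibition of C-X-C chemokine receptor type 3 (Homo sapiens), with a stated time of 30 min (a lower number here means a stronger inhibitor, a higher number a weaker inhibitor), compound 1 gives 289 nM and compound 2 gives 90 nM. Among the compounds with values here, the only measured step, a 3.2-fold lower number from compound 1 to compound 2 (0.51 log units; beyond the scatter), shows that the substituent on the pyrazole ring moves the number by a modest amount. Compound 2 therefore stands lowest of the two numbers, with compound 1 the nearest at a higher number beyond the scatter.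

Compound 3 `CCOc1ncc(-c2nc(C(F)(F)F)sc2N2CCN(C(=O)Cn3cc(Cl)cn3)[C@H](C)C2)cn1` has not been measured in this assay. It differs from compound 2 in one place: 4-chloro-1H-pyrazol-1-yl in place of 3-(trifluoromethyl)-1H-pyrazol-1-yl on a saturated chain carbon bound to a carbonyl carbon. Within the data shown here, no measured step swaps a pyrazole substituent for a halogen, so the step from compound 1 to compound 2 is the only guide; it concerns the same ring in the same place and says only that such a change can shift the number modestly, in either direction. For compound 3 the expected step in this assay is a 1.7-fold higher number from compound 2 to compound 3 (0.22 log units; within the scatter), most likely a somewhat higher number. The estimate for compound 3 is 150 nM, with a range from 50 nM to 450 nM.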

Compound 3, half-maximal inhibitory concentration: 245 nM
For compound 3 the middle estimate is 1.6-fold (0.21 log units) below the measured one; the range from low to high includes it.
By their numbers in this assay, from the lowest: compound 2; then compounds 3 and 1 (each within the scatter of the next).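

In this assay, 4-chloro-1H-pyrazol-1-yl does not keep the lower number seen with 3-(trifluoromethyl)-1H-pyrazol-1-yl on the saturated chain carbon bound to a carbonyl carbon: this change gives a 2.7-fold higher number from compound 2 to compound 3 (0.43 log units; beyond the scatter) and so shows that a halogen-bearing pyrazole here does not match the trifluoromethyl one. Set against 5-methyl-1H-pyrazol-1-yl, the chloro group shows no separation, with a 1.2-fold lower number from compound 1 to compound 3 (0.07 log units; within the scatter), so of the three pyrazoles only the 3-(trifluoromethyl)-1H-pyrazol-1-yl stands apart, while the methyl and chloro groups cannot be told apart at this position. No measurement is at hand that would account for this difference among the three groups.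

The substituent and its place on the pyrazole change together across these compounds, so the contribution of each cannot be read separately. Also open, as far as these compounds go, is how a pyrazole carrying a nitrile or a carboxylic acid, or a longer chain in place of the single saturated chain carbon, would read in this assay.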